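The source may report more compounds than this note shows. Statements on the series, on what has been measured and on what is new or still open speak of the compounds shown alone.

Of the compounds shown here, three that share one core have been measured in a functional assay on HT-29 cells (Homo sapiens) for inhibition, with a stated time of 72 h (a lower number here means a stronger inhibitor, a higher number a weaker inhibitor), so far. Compound 1 (`COc1ccc(S(=O)(=O)N2CCc3cccc(-c4ccco4)c32)cc1`), with a furan-2-yl group, gives 62.5 nM in this read-out. Compound 2 (`COc1ccc(S(=O)(=O)N2CCc3cccc(-c4ccc(F)cc4)c32)cc1`), with a 4-fluorophenyl group, gives 85.5 nM there. Compound 3 (`COc1ccc(S(=O)(=O)N2CCc3cccc(-c4ccncc4)c32)cc1`), with a pyridin-4-yl group, gives 87.5 nM and stands within the scatter of both others. Compound 4 (`COc1ccc(S(=O)(=O)N2CCc3cccc(-c4cccnc4)c32)cc1`) is still unmeasured. It has pyridin-3-yl in place of pyridin-4-yl on an aromatic carbon, so the two compounds hold the same atoms, joined differently.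

Among the measured compounds shown here, the steps that bear on this change swap the group at that same carbon. They are small: a 1.4-fold higher number from compound 1 to compound 2 (0.14 log units; within the scatter) and a 1.4-fold higher number from compound 1 to compound 3 (0.15 log units; within the scatter) are joined by a 1.0-fold higher number from compound 2 to compound 3 (0.01 log units; within the scatter) as the closest parallel, since it also ends on compound 3. All three lie within the scatter, even though a five-membered ring, a fluorinated ring and a pyridine ring were exchanged. For the measured compounds named here, no measured compound carries pyridin-3-yl, so this remains an inference. No step beyond the scatter is expected in this assay in either direction, and the estimated change is a 1.0-fold lower number from compound 3 to compound 4 (0.01 log units; within the scatter) at most a nominal one. For compound 4 the expected value is 85 nM with an estimated range of 45 nM to 160 nM in this read-out.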

Compound 4, half-maximal inhibitory concentration: 76.3 nM
Estimate against measurement, compound 4: 1.1-fold (0.05 log units) above; the measured number falls inside the stated range.
By their numbers in this assay, from the lowest: compounds 1, 4, 2 and 3 (each within the scatter of the next).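

Pyridin-3-yl in place of pyridin-4-yl gives a step within the scatter in this assay (a 1.1-fold lower number from compound 3 to compound 4 (0.06 log units; within the scatter)), so at this aromatic carbon of the shared core, the point of attachment on the pyridine ring makes no readable difference, although the atoms stay the same and only their joining changes. The earlier compounds shown here showed only exchanges between different kinds of ring, whereas this pair tests a rearrangement within one ring, and compound 4 also stays within the scatter of the other two groups (a 1.1-fold lower number from compound 2 to compound 4 (0.05 log units; within the scatter); a 1.2-fold higher number from compound 1 to compound 4 (0.09 log units; within the scatter)), so furan-2-yl, 4-fluorophenyl and both pyridine attachments all read alike in this assay. Nothing available explains why these groups give such similar numbers.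

As far as these compounds go, all four compounds carry an aromatic ring at this carbon, so it remains open whether a piperidine, a carboxylic acid or a butyl chain there would stay within the same narrow band. The methoxy group and the sulfonyl link are also identical across the four compounds, which leaves the effect of any change at those places in this assay unknown.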